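A few compounds are considered here, and "the series" means these few. Any claim that something is new, unique, unknown or untested is made for them only; others in the source may bear on it.

Working notes on the acrylamide series.

For the measured compounds named here, compound 1, `C=CC(=O)Nc1cc(Nc2ncnc(Nc3ccc(C(=O)N4CCCCC4)cc3)n2)ccc1C`, is the only member with a numerical result: in a functional assay on Ramos cells (Homo sapiens) for antiproliferative activity, read by CCK-8 assay, with a stated time of 24 h (a lower number here means a stronger inhibitor, a higher number a weaker inhibitor), compound 1 gives 48500 nM. Compound 2, `C=CC(=O)Nc1cccc(Nc2ncnc(Nc3ccc(Oc4ccc(OC)cc4)cc3)n2)c1`, carries a 4-methoxyphenoxy group in the position that compound 1 fills with a piperidine amide. For compound 2 this assay reports only a limit, > 100000 nM. Going by the values given here, compound 2 therefore stands at the limit of > 100000 nM in this assay, at which 1 of the 2 values shown sits, the weaker end of what has been measured so far, and no step between compound 1 and compound 2 can be sized beyond that.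

Compound 3, `C=CC(=O)Nc1cccc(Nc2ncnc(Nc3ccc(-c4ccc(F)nc4)cc3)n2)c1`, is not yet measured. It differs from compound 2 in one place: 6-fluoropyridin-3-yl in place of 4-methoxyphenoxy on an aromatic carbon. Since compound 2 is known only as a limit, the size of this step cannot be anchored, and the direction is open; in this assay the expected step is an at least 1.4-fold lower number from compound 2 to compound 3 (0.15 log units; that floor lies within the scatter), which lies within the scatter of the method. Compound 3 is expected at 70000 nM, with a range from 25000 nM to 200000 nM, and a fair chance that the assay again returns only a limit.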

Compound 3, half-maximal inhibitory concentration: 59200 nM
Compound 3: the middle estimate sits 1.2-fold (0.07 log units) above what was measured, within the range that was stated.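

For the compounds shown here, exchanging 4-methoxyphenoxy for 6-fluoropyridin-3-yl on this aromatic carbon, para to a large group, gives the first number for this position on the core of compound 2: in this assay compound 3 gives 59200 nM. The change reads as an at least 1.6-fold lower number from compound 2 to compound 3 (0.22 log units; that floor lies within the scatter); this figure is only a floor, and the true size of the change may be larger. Compound 2 itself remains a limit and not a number: the limit of > 100000 nM in this assay, at which 1 of the 3 values shown sits.

The compounds shown do not separate the ring nitrogen from the fluorine of 6-fluoropyridin-3-yl, and a plain pyridin-3-yl or a 4-fluorophenyl group on this carbon would draw that line. Also open, as far as these compounds go, is how the position answers to a group without an aromatic ring, such as an amine, a carboxylic acid or a longer chain, and whether any such group brings the number in this assay clearly down from where compound 3 stands.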